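Methyl on the shared core: expected growth inhibition shift

A few compounds are considered here, and "the series" means these few. Any claim that something is new, unique, unknown or untested is made for them only; others in the source may bear on it.

For the measured compounds named here, in a functional assay on cells (Cancer cell lines, Homo sapiens) for inhibition (on this read-out higher numbers stand for weaker inhibition of growth and lower numbers for stronger inhibition of growth), compound 2 (`N=C(N)N/N=C/c1c(-c2cccs2)nc2sccn12`) gives 29500 nM and compound 1 (`Cc1cn2c(/C=N/NC(=N)N)c(-c3ccsc3)nc2s1`) gives 41700 nM as the only other number available. Going by the values given here, the two values lie within the usual scatter of each other, so compound 2 stands level with compound 1 on this evidence, and the series so far shows no measurable spread.

Compound 3 (`Cc1cn2c(/C=N/NC(=N)N)c(-c3cccs3)nc2s1`) departs from compound 2 by one change (methyl in place of hydrogen on an aromatic carbon), methyl in place of hydrogen on an aromatic carbon of the shared core. Among the compounds with values here, no measured pair isolates this change, so its size cannot be read directly from the data. In this assay a step beyond the scatter is not expected, and no direction can be favoured with confidence. This expectation rests only on compound 2 at 29500 nM and compound 1 at 41700 nM sitting close together. The expected outcome is a 1.1-fold higher number from compound 2 to compound 3 (0.04 log units; within the scatter) and this estimated step stays within the scatter. For compound 3 the estimated value is 32000 nM with an expected range from 15000 nM to 65000 nM in this read-out.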

Compound 3, concentration for total growth inhibition: 25100 nM
Compound 3: the middle estimate sits 1.3-fold (0.11 log units) above what was measured, within the range that was stated.
By their numbers in this assay, from the lowest: compounds 3, 2 and 1 (each within the scatter of the next).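

In this assay, for the compounds shown here, the first pair that isolates methyl in place of hydrogen on an aromatic carbon of the shared core, next to the ring sulfur, gives a 1.2-fold lower number from compound 2 to compound 3 (0.07 log units; within the scatter), so on this read-out the methyl at this position produces no step that can be told from the scatter. With the methyl held in place, thiophen-2-yl in place of thiophen-3-yl gives a 1.7-fold lower number from compound 1 to compound 3 (0.22 log units; within the scatter), so the attachment point of the thiophene also stays inside the scatter, even though this is the wider of the two steps. Each single change can now be read on its own, and neither separates its two compounds in this assay, while nothing available speaks to why either step has this size.

The compounds shown leave open whether an amine, a carboxylic acid or a longer chain on this same aromatic carbon would give a step beyond the scatter. With only hydrogen and methyl compared here, they also leave open whether this position can influence growth inhibition at all.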